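This account rests on a few compounds, and the source may have more. Where it says the series, first, only, none or still open, it means among the compounds named here.

Compound 1 `Cc1cccc(C)c1CC1CN/C(=N\N(C)C)CN(CC(=O)Nc2cccc(-c3cnn(C)c3)c2)C1=O` was tested in an assay on isolated protein for inhibition of kallikrein-7 (Mus musculus), read by fluorescence, with stated times of 10 min and 30 min (on this read-out lower numbers stand for stronger inhibition and higher numbers for weaker inhibition), where compound 1 gives 3800 nM, the highest of the two single numbers in hand. Its nearest neighbour is compound 2 `Cc1cccc(Cl)c1CC1CN/C(=N\N(C)C)CN(CC(=O)Nc2cccc(-c3cnn(C)c3)c2)C1=O`, which in this assay gives 1600 nM; the step of a 2.4-fold lower number from compound 1 to compound 2 (0.38 log units; beyond the scatter) came with chloro in place of methyl on an aromatic carbon. Compound 3 `CN(C)/N=C1/CN(CC(=O)Nc2cccc(-c3cnn(C)c3)c2)C(=O)C(Cc2c(Cl)cccc2Cl)CN1` carries a chloro on both sides and gives 1200 nM; 16000 nM; 700 nM (3 entries) in this assay, a spread set out in the several entries of compound 3 in this assay, 1200 nM; 16000 nM; 700 nM (3 entries). Compound 4 `CN(C)/N=C1/CN(CC(=O)Nc2cccc(-c3cnn(C)c3)c2)C(=O)C(Cc2c(F)cccc2F)CN1` differs from compound 1 by 2,6-difluorophenyl in place of 2,6-dimethylphenyl on a saturated chain carbon bound to a saturated ring carbon. Only the modest step from compound 1 to compound 2 bears on it, and fluoro is not chloro, so a step toward a lower number of similar or smaller size is expected, a 1.7-fold lower number from compound 1 to compound 4 (0.24 log units; within the scatter). Compound 4 is therefore estimated at 2200 nM, between 700 nM and 7000 nM.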

Compound 4, half-maximal inhibitory concentration: > 30000 nM
Compound 4: no number, only a limit; the forecaster's own chance of this, stated with the estimate: 5%; at least 13-fold (1.13 log units) between middle value and limit.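

In this assay compound 4 gives only a limit, > 30000 nM, and not a number. Even so, the change at this place runs against the earlier chloro step, with an at least 7.8-fold higher number from compound 1 to compound 4 (0.89 log units; beyond the scatter) and an at least 18-fold higher number from compound 2 to compound 4 (1.27 log units; beyond the scatter), so swapping the groups on this aromatic ring does not move the number in one direction. Compound 3 offers no single value for comparison: the several entries of compound 3 in this assay, 1200 nM; 16000 nM; 700 nM (3 entries)

As far as these compounds go, how far past the limit compound 4 lies stays open. So does how a plain benzyl or a 2,6-dibromobenzyl would read at this place.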